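A few compounds are considered here, and "the series" means these few. Any claim that something is new, unique, unknown or untested is made for them only; others in the source may bear on it.

Working notes on the series. Compound 1 `COc1ccc(/C=C/C(=O)c2ccccc2NC(=O)NS(=O)(=O)c2ccc(C)cc2)cc1` carries a 4-methoxyphenyl on a double-bonded chain carbon bound to a double-bonded chain carbon. In an ADME assay on the whole organism for cytotoxicity, with Artemia salina as the target, with a stated time of 24 h (on this read-out higher numbers stand for an effect only at larger amounts of compound and lower numbers for an effect already at smaller amounts), compound 1 gives 28.1 ug/mL, the second highest of the three numbers in hand. In this assay compound 2 `Cc1ccc(S(=O)(=O)NC(=O)Nc2ccccc2C(=O)/C=C/c2cccc([N+](=O)[O-])c2)cc1` gives 44.5 ug/mL, with a 1.6-fold higher number from compound 1 to compound 2 (0.20 log units; within the scatter). In this assay compound 3 `Cc1ccc(S(=O)(=O)NC(=O)Nc2ccccc2C(=O)/C=C/c2ccc(Cl)cc2)cc1` gives 6.92 ug/mL, with a 4.1-fold lower number from compound 1 to compound 3 (0.61 log units; beyond the scatter) and a 6.4-fold lower number from compound 2 to compound 3 (0.81 log units; beyond the scatter).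

Compound 4 `Cc1ccc(S(=O)(=O)NC(=O)Nc2ccccc2C(=O)/C=C/c2ccc(Cl)cc2Cl)cc1` is not yet measured. Its difference from compound 1: 2,4-dichlorophenyl in place of 4-methoxyphenyl on a double-bonded chain carbon bound to a double-bonded chain carbon. Of the measured steps, the one carrying chloro in place of methoxy bears most directly on this change, and it was a modest step to a lower number; the step carrying 3-nitrophenyl stayed within the scatter. Going by the values given here, a 2,4-dichlorophenyl entering brings a second chloro, for which no measured pair gives a step, so the direction is taken from the single chloro and its size is left open. For compound 4 a modest step to a lower number is therefore expected in this assay, because of a 4.1-fold lower number from compound 1 to compound 3 (0.61 log units; beyond the scatter). The expected step is a 4.3-fold lower number from compound 1 to compound 4 (0.64 log units; beyond the scatter). The estimated value of compound 4 in this assay is 6.5 ug/mL, within a range from 2.5 ug/mL to 17 ug/mL.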

Compound 4, concentration for half-maximal effect: 8.34 ug/mL
For compound 4 the middle estimate is 1.3-fold (0.11 log units) below the measured one; the measured number falls inside the stated range.
By their numbers in this assay, from the lowest: compounds 3 and 4 (each within the scatter of the next); then compounds 1 and 2 (each within the scatter of the next).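

Going by these compounds alone, the second chloro is the first addition made to the 4-chlorophenyl, and it does not separate the two compounds in this assay: there is a 1.2-fold higher number from compound 3 to compound 4 (0.08 log units; within the scatter), so 2,4-dichlorophenyl and 4-chlorophenyl read alike at this place on the double-bonded chain carbon. The lower number seen with a single chloro also holds with two, with a 3.4-fold lower number from compound 1 to compound 4 (0.53 log units; beyond the scatter) and a 5.3-fold lower number from compound 2 to compound 4 (0.73 log units; beyond the scatter) as the steps from the two compounds without chloro. Among these four compounds, the two carrying chloro therefore stand apart from the 4-methoxyphenyl and 3-nitrophenyl compounds, and none of the four goes against this split, though nothing available on these compounds accounts for it.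

From the compounds shown here alone, it remains open whether the lower numbers belong to chloro itself or would also appear with a bromo or a methyl on this phenyl, and whether a 2-chlorophenyl alone would read like the 4-chlorophenyl. Going by these compounds, how an amine or a carboxylic acid on this phenyl would move the number, and in which direction, also stays open.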